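A few compounds are considered here, and "the series" means these few. Any claim that something is new, unique, unknown or untested is made for them only; others in the source may bear on it.

Measured compounds in a toxicity assay on NIH3T3 cells (Mus musculus) for cytotoxicity, read by resazurin assay; on this read-out lower numbers stand for an effect already at smaller amounts and higher numbers for an effect only at larger amounts of compound:
- Compound 1 `COC(=O)c1ccc(NCc2cncn2Cc2ccccc2Cl)cc1-c1ccccc1` gives 10000 nM in this assay.
- Compound 2 `c1ccc(-c2ccc(Cn3cncc3CNc3ccc(-c4onc5ccccc45)c(-c4ccccc4)c3)cc2)cc1` gives > 10000 nM in this assay, which is a limit and not a number.
- Compound 3 `COC(=O)c1ccc(NCc2cncn2Cc2ccc(C#N)cc2)cc1-c1ccccc1` gives > 10000 nM in this assay, which is a limit and not a number.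

Compound 2 thus stands at the limit of this assay, and one of the other two values shown is a limit as well; only compound 1 gives a number, and that number sits at the limit value itself.

Compound 4 `c1ccc(-c2ccc(Cn3cncc3CNc3ccc(-c4noc5ccccc45)c(-c4ccccc4)c3)cc2)cc1` differs from compound 2 by a group of 9 heavy atoms (7 carbon, 1 nitrogen, 1 oxygen; one five-membered aromatic ring with 2 hetero atoms, one six-membered aromatic ring of carbon only) in place of a group of 9 heavy atoms (7 carbon, 1 nitrogen, 1 oxygen; one five-membered aromatic ring with 2 hetero atoms, one six-membered aromatic ring of carbon only), on an aromatic carbon; the two compounds have the same atoms, joined differently, and the place of the change is on an aromatic carbon of a six-membered aromatic ring of carbon only, ortho to a phenyl group and para to a large group.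

Among the measured compounds shown here, the only measured step, a number no lower from compound 1 to compound 3 (the limit leaves the size open), concerns a different position and leaves its size open, so it bears on the present change only weakly. Given (the limit of > 10000 nM in this assay, at which 2 of the 3 values shown sit), no step beyond the usual scatter is expected in this assay, and the step from compound 2 to compound 4 is estimated as a step that the limit leaves unreadable from compound 2 to compound 4.

For compound 4 the expected value in this assay is therefore 15000 nM, with a range from 6000 nM to 40000 nM, most likely reported again as a limit.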

Compound 4, half-maximal effective concentration: > 10000 nM
Compound 4: only a limit was reported; the forecaster's own chance of this, stated with the estimate: 80%; the middle value lies beyond the limit too.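

No step can be read from compound 2 to compound 4 in this assay, since both results are limits and not numbers: the limit of > 10000 nM in this assay, at which 3 of the 4 values shown sit.

As far as these compounds go, whether exchanging these two groups, made of the same atoms joined differently, changes the half-maximal effective concentration at all in this assay stays open, as does the size of any such change.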